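A few compounds are considered here, and "the series" means these few. Any claim that something is new, unique, unknown or untested is made for them only; others in the source may bear on it.

Compound 1 `CNC(=O)c1cc(C(=O)N[C@H]2CC[C@H](O)CC2)c([C@@H](C)c2cccc(Cl)c2)o1` and compound 2 `CNC(=O)c1cc(C(=O)N[C@H]2CC[C@H](O)CC2)c([C@@H](C)c2ccccc2)o1` share one core, while compound 3 `CNC(=O)c1cc(C(=O)N[C@H]2[C@@H]3C[C@@H](O)C[C@@H]32)n([C@@H](C)c2cccc(Cl)c2)n1` and compound 4 `CNC(=O)c1cc(C(=O)N[C@H]2[C@@H]3C[C@@H](O)C[C@@H]32)n([C@@H](C)c2ccccc2)n1` share another; how the two cores differ is not broken down here. In a physicochemical assay for lipophilicity (a lower number here means a more polar compound, a higher number a more lipophilic compound), compound 1 gives 3.5, compound 2 gives 2.8, and compound 3 gives 3.4, a number within the scatter of that for compound 1. The change from compound 1 to compound 2 is hydrogen in place of chloro on an aromatic carbon, and with it the distribution coefficient fell: a number 0.70 log units lower from compound 1 to compound 2 (beyond the scatter). From compound 3 to compound 4 the same change is made, (hydrogen in place of chloro on an aromatic carbon). Resting on the one measured step of this kind, a number 0.70 log units lower from compound 1 to compound 2 (beyond the scatter), a step of the same size is expected here: a number 0.70 log units lower from compound 3 to compound 4 (beyond the scatter). Compound 4 is thus estimated at 2.7, with a likely range from 2.4 to 3.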

Compound 4, distribution coefficient: 3.2
Compound 4: the middle estimate sits 0.50 log units below what was measured; measured number outside the range, above it.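

In this assay, hydrogen in place of chloro on an aromatic carbon gave a number 0.20 log units lower from compound 3 to compound 4 (within the scatter), while the same change on the other core gave a number 0.70 log units lower from compound 1 to compound 2 (beyond the scatter). The step seen on the core of compound 1 therefore did not carry over at that size to the core of compound 3, so in this series its size cannot be assumed to transfer between these cores. With one pair on each core, this does not establish a general rule for either core, and nothing shown explains the result.

The compounds shown leave open how a fluoro, methoxy or nitrile group in place of the chloro would behave on each core. They also leave open whether any such step would carry from one core to the other.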